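A few compounds are considered here, and "the series" means these few. Any claim that something is new, unique, unknown or untested is made for them only; others in the source may bear on it.

Working notes on the series in a functional assay on DU-145 cells (Homo sapiens) for antiproliferative activity, read by MTT assay; on this read-out lower numbers stand for stronger inhibition and higher numbers for weaker inhibition. Compound 1 `Cc1nn2c(-c3nc4c(C)c(C)ccc4[nH]3)c(-c3ccccc3)nc2s1` reports only a limit, > 30000 nM. Compound 2 `Cc1ccc(-c2nc3sc(C)nn3c2-c2nc3cc(Cl)ccc3[nH]2)cc1` gives 7300 nM. Compound 3 `Cc1ccc(-c2nc3sc(C)nn3c2-c2nc3cc(C)ccc3[nH]2)cc1` gives 10700 nM. These two numbers lie within the scatter of each other, with a 1.5-fold higher number from compound 2 to compound 3 (0.17 log units; within the scatter), so compound 3 stands level with compound 2 in this assay, and the only other result is the limit.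

Compound 4 `Cc1ccc(-c2nc3sc(C)nn3c2-c2nc3c(C)c(C)ccc3[nH]2)cc1` is reached from compound 3 by methyl in place of hydrogen on an aromatic carbon. This is methyl in place of hydrogen on an aromatic carbon of the six-membered aromatic ring of carbon only, ortho to a methyl group and ortho to a fused ring.

Among the measured compounds shown here, only one measured step bears on this, and it is a different change: methyl in place of chloro on an aromatic carbon, seen as a 1.5-fold higher number from compound 2 to compound 3 (0.17 log units; within the scatter). It gives no sign of a large effect from a small substituent swap on that ring. The other guide is compound 1, which stays at its limit of > 30000 nM and so leans the expectation towards a higher number rather than a lower one. The expected shift is therefore small and may not clear the scatter, estimated as a 1.4-fold higher number from compound 3 to compound 4 (0.15 log units; within the scatter). For compound 4 the estimated value is 15000 nM, with an expected range from 6500 nM to 30000 nM.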

Compound 4, half-maximal inhibitory concentration: 12500 nM
Compound 4: middle estimate off by 1.2-fold (0.08 log units), on the high side, and the stated range covers the measured number.
By their numbers in this assay, from the lowest: compounds 2, 3 and 4 (each within the scatter of the next). At a limit, above all of these: compound 1.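

In this assay, methyl in place of hydrogen on an aromatic carbon of the six-membered aromatic ring of carbon only, ortho to a methyl group and ortho to a fused ring, gives a 1.2-fold higher number from compound 3 to compound 4 (0.07 log units; within the scatter), so compound 3 and compound 4 stand level. This is the second step on that ring to stay within the scatter, after a 1.5-fold higher number from compound 2 to compound 3 (0.17 log units; within the scatter), and the first to add a group there rather than swap one. The same kind of change at a different aromatic carbon gives an at least 2.4-fold lower number from compound 1 to compound 4 (0.38 log units; beyond the scatter), the only new step beyond the scatter, and its true size stays unknown since compound 1 reports only a limit: the limit of > 30000 nM in this assay, at which 1 of the 4 values shown sits.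

Going by these compounds, whether a larger or different group on the ring that carries the two methyl groups, such as an amine, a carboxylic acid or a longer alkyl chain, would move the number beyond the scatter remains open. Also open, on these data alone, is whether the methyl that separates compound 1 from compound 4 would give a step of similar size with other substituents on that ring.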